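A methylated piperazine in place of the free one

The source may report more compounds than this note shows. Statements on the series, on what has been measured and on what is new or still open speak of the compounds shown alone.

In a toxicity assay on HEK-293T cells (Homo sapiens) for cytotoxicity, read by MTT assay, with a stated time of 72 h (a higher number here means a weaker inhibitor, a lower number a stronger inhibitor), compound 1 `O=C1c2c[n+]([O-])c3ccccc3c2C(=O)c2c1c1ccccc1n2Cc1cn(CC(O)CO)nn1` gives 760 nM and compound 3 `O=C1c2c[n+]([O-])c3ccccc3c2C(=O)c2c1c1ccccc1n2CCCCN1CCNCC1` shares that top number of the three at 760 nM while compound 2 `CN1CCN(CCCCn2c3c(c4ccccc42)C(=O)c2c[n+]([O-])c4ccccc4c2C3=O)CC1` gives 100 nM as the lowest. Compound 4 `CN1CCN(CCCn2c3c(c4ccccc42)C(=O)c2c[n+]([O-])c4ccccc4c2C3=O)CC1` differs from compound 3 by 4-methylpiperazin-1-yl in place of (piperazin-1-yl)methyl on a saturated chain carbon, three bonds along the chain from an aromatic nitrogen on a saturated chain carbon, three bonds along the chain from an aromatic nitrogen. Cut one bond further out, the same difference reads 4-(piperazin-1-yl)butyl to 3-(4-methylpiperazin-1-yl)propyl. The closest measured change is hydrogen in place of methyl on an amine nitrogen in a ring, which gave a 7.6-fold higher number from compound 2 to compound 3 (0.88 log units; beyond the scatter) and which, read in reverse, points to a lower number for compound 4. Among the measured compounds shown here, no measured pair isolates the change in chain, so that part of the difference remains open. A modest fall is therefore expected, namely a 5.8-fold lower number from compound 3 to compound 4 (0.77 log units; beyond the scatter) as the estimated step. Compound 4 is thus estimated at 130 nM with a range of 40 nM to 400 nM expected.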

Compound 4, half-maximal inhibitory concentration: 170 nM
The estimate for compound 4 lay 1.3-fold (0.12 log units) below the measured number; low and high end bracket the measured number.
By their numbers in this assay, from the lowest: compounds 2 and 4 (each within the scatter of the next); then compounds 1 and 3 (each within the scatter of the next).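

In this assay, among the compounds shown here, the change in chain that no earlier pair isolated now has a measured step: 4-methylpiperazin-1-yl in place of (4-methylpiperazin-1-yl)methyl at this position gives a 1.7-fold higher number from compound 2 to compound 4 (0.23 log units; within the scatter) and so stays within the scatter. Set against the free piperazine, the same methylated side chain gives a 4.5-fold lower number from compound 3 to compound 4 (0.65 log units; beyond the scatter) and set against the group of compound 1, with 2-(4-methylpiperazin-1-yl)ethyl in place of 1-(2,3-dihydroxypropyl)-1H-1,2,3-triazol-4-yl, it gives a 4.5-fold lower number from compound 1 to compound 4 (0.65 log units; beyond the scatter) with both steps beyond the scatter. No supporting measurement is available to explain these steps.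

On these data alone, whether the change in chain would read the same with a free piperazine remains open. So does what a morpholine or a dimethylamine at the end of the chain would give.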